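From Cyclopropyl to Methyl on an Amide-Type Nitrogen

The compounds below may be only part of what the source reports. "The series", "measured", "known", "first", "only" and "open" are said of these compounds alone.

This piece follows compound 3 `O=C(NC1CC1)c1ncc([N+](=O)[O-])[nH]1` in a toxicity assay on HEK293 cells (Homo sapiens) for inhibition, read by resazurin assay, with a stated time of 24 h; a lower number here means that less compound is tolerated, a higher number that more compound is tolerated. Compound 3 gives > 100000 nM, which is a limit of the assay and not a number. Compound 1 `Cn1c([N+](=O)[O-])cnc1C(=O)NC1CC1` gives > 100000 nM, again a limit. Compound 2 `CN(C)C(=O)c1ncc([N+](=O)[O-])[nH]1` gives > 100000 nM, also a limit. The evidence so far is therefore (the limit of > 100000 nM in this assay, at which 3 of the 3 values shown sit).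

The next compound, compound 4 `CNC(=O)c1ncc([N+](=O)[O-])[nH]1`, differs from compound 3 as follows: methyl in place of cyclopropyl on an amide-type nitrogen. In short, it carries methyl in place of cyclopropyl on an amide-type nitrogen.

For the measured compounds named here, two measured steps bear on this change. Putting hydrogen in place of methyl on an aromatic nitrogen is a step that the two limits leave unreadable from compound 1 to compound 3. Closer to the new change, putting cyclopropylamino in place of dimethylamino on a carbonyl carbon is a step that the two limits leave unreadable from compound 2 to compound 3. Neither step has a readable size, so neither points in a direction, and no number has yet appeared in this series. Nothing beyond the usual scatter is therefore expected, and the expected change is a number no higher from compound 3 to compound 4 (the limit leaves the size open). The assay may well report only a limit again. In this assay the estimate for compound 4 is 100000 nM, with an expected range from 50000 nM to 200000 nM.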

Compound 4, half-maximal cytotoxic concentration: > 100000 nM
Compound 4: a limit, no number; the forecaster's own chance of this, stated with the estimate: 85%; the middle value sits exactly at the limit.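

Compound 4 ends at a limit of the assay and gives no number, as do compound 2 and compound 3, so neither of its two new steps, from compound 3 or from compound 2, can be read. The compounds shown leave open whether any of these changes alters how much compound the cells tolerate, as all of them stand at one place: the limit of > 100000 nM in this assay, at which 4 of the 4 values shown sit.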